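This account rests on a few compounds, and the source may have more. Where it says the series, first, only, none or still open, it means among the compounds named here.

Within the data shown here, compound 2 `Cc1nn(C)c2c1C(c1cccnc1)C(C#N)=C(N)O2` gives 8800 nM in a functional assay on NCI-H2122 cells (Homo sapiens) for inhibition, read by microscopy, with a stated time of 10 days (a lower number here means a stronger inhibitor, a higher number a weaker inhibitor), and stands as the lower of the two numbers so far, within the scatter of compound 1 `Cc1nn(C)c2c1C(c1ccccc1)C(C#N)=C(N)O2`, which gives 9100 nM. Among the measured compounds shown here, the single measured step, a 1.0-fold lower number from compound 1 to compound 2 (0.01 log units; within the scatter), replaced the aryl group on a saturated ring carbon without moving the number. Compound 3 `Cc1nn(C)c2c1C(c1cccc(Br)n1)C(C#N)=C(N)O2` carries 6-bromopyridin-2-yl in place of pyridin-3-yl on a saturated ring carbon. For the measured compounds named here, only that flat step bears on this change, so in this assay no step beyond the scatter from compound 2 to compound 3 is expected, the added bromine being an unknown. Compound 3 is expected near 7500 nM, range 2500 nM to 22000 nM, an expected step of a 1.2-fold lower number from compound 2 to compound 3 (0.07 log units; within the scatter).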

Compound 3, half-maximal inhibitory concentration: 2400 nM
Beside the measured number, compound 3's estimate is 3.1-fold (0.49 log units) above it, and the stated range ends above it.
By their numbers in this assay, from the lowest: compound 3; then compounds 2 and 1 (each within the scatter of the next).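

In this assay, the aryl group on the saturated ring carbon can move the number beyond the scatter: 6-bromopyridin-2-yl gives a 3.7-fold lower number from compound 2 to compound 3 (0.56 log units; beyond the scatter) and a 3.8-fold lower number from compound 1 to compound 3 (0.58 log units; beyond the scatter). The exchange of phenyl for pyridin-3-yl had shown no such movement. No supporting data bear on the cause of these steps.

The steps combine a different pyridine attachment with an added bromine, and the compounds shown do not separate the two. As far as these compounds go, whether plain pyridin-2-yl, or a chlorine or an amine in place of the bromine, would keep the lower number remains open.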